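This account rests on a few compounds, and the source may have more. Where it says the series, first, only, none or still open, it means among the compounds named here.

Going by the values given here, compound 2 `COC(=O)c1ccc(CN2CCC(O)(Cn3cnc4c(cnn4-c4ccc(F)cc4)c3=O)CC2)c(F)c1` is the only one with a number in an assay on Sf21 cells for inhibition of ubiquitin carboxyl-terminal hydrolase 7 (Homo sapiens), read by spectrophotometry, with stated times of 30 min and 2 h (on this read-out higher numbers stand for weaker inhibition and lower numbers for stronger inhibition), where it gives 800 nM; compound 1 `Cc1ccc(CN2CCC(O)(Cn3cnc4c(cnn4-c4ccc(F)cc4)c3=O)CC2)cc1` has no result reported there, its entry reading "not determined" (no result reported), so compound 2 stands alone. Compound 3 `COC(=O)c1ccc(CN2CCC(O)(Cn3cnc4c(cnn4-c4ccc(F)cc4)c3=O)CC2)c(Cl)c1` differs from compound 2 by chloro in place of fluoro on an aromatic carbon. No measured pair follows this change, so nothing shown speaks for a shift beyond the scatter in either direction, and for compound 3 the step is expected to be small, at a 1.1-fold lower number from compound 2 to compound 3 (0.06 log units; within the scatter). In this assay compound 3 is therefore estimated at 700 nM, within 300 nM to 1600 nM.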

Compound 3, half-maximal inhibitory concentration: 800 nM
Compound 3: middle estimate off by 1.1-fold (0.06 log units), on the low side, and the stated range covers the measured number.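

Chloro in place of fluoro on this aromatic carbon, ortho to a large group, gives no change at the digits printed from compound 2 to compound 3 (within the scatter) in this assay, the only step that can be read here. At this position, then, the two halogens cannot be told apart on this read-out, and the 2-chloro-4-(methoxycarbonyl)benzyl group does as well as its 2-fluoro counterpart. No measurement at hand offers any explanation for this result.

The compounds shown leave open whether a group other than a halogen, such as a methoxy or an amine, would hold the number at this position. They also leave open what a carboxylic acid in place of the methoxycarbonyl group would do.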